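Lifting the half-life of compound 3 with an amide

A few compounds are considered here, and "the series" means these few. Any claim that something is new, unique, unknown or untested is made for them only; others in the source may bear on it.

Compound 1 `CC(C)n1cc(-c2ccnc3[nH]c(C4CCN(CC(=O)N5CCCC5)CC4)cc23)ccc1=O`: 1.1 h
Compound 2 `COc1cc(F)ccc1-c1ccnc2[nH]c(C3CCN(CC(=O)N(C)C)CC3)cc12`: 1 h
Compound 3 `CC(C)n1cc(-c2ccnc3[nH]c(C4CCN(Cc5cccs5)CC4)cc23)ccc1=O`: 0.4 h

In an ADME assay (Rattus norvegicus, strain Han-wistar) for metabolic stability, at a dose of 1.5 umol/kg by the intravenous route (a lower number here means that the compound disappears faster, a higher number that the compound lasts longer), compound 3 gives 0.4 h, the lowest number of the three, and compound 2 and compound 1 both stand above it by more than the scatter. Compound 4 `CC(C)n1cc(-c2ccnc3[nH]c(C4CCN(CC(=O)N(C)C)CC4)cc23)ccc1=O` differs from compound 3 in one group: dimethylcarbamoyl in place of thiophen-2-yl on a saturated chain carbon bound to an amine nitrogen in a ring. The measured step that bears on this is a 2.8-fold lower number from compound 1 to compound 3 (0.44 log units; beyond the scatter), which brought in thiophen-2-yl in place of (pyrrolidin-1-yl)carbonyl on the same saturated chain carbon. The change to compound 4 runs the opposite way, though to a different amide, so a rise of about that modest size is expected. Compound 2 also carries dimethylcarbamoyl there and gives 1 h, but the rest of its structure differs. For the measured compounds named here, no measured pair isolates the two amides from each other. The expected change is a 2.5-fold higher number from compound 3 to compound 4 (0.40 log units; beyond the scatter). For compound 4 the estimated half-life is 1 h, with an expected range from 0.6 h to 1.7 h.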

Compound 4, half-life: 1.7 h
For compound 4 the middle estimate is 1.7-fold (0.23 log units) below the measured one; low and high end bracket the measured number.
By their numbers in this assay, from the lowest: compound 3; then compounds 2, 1 and 4 (each within the scatter of the next).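

On the saturated chain carbon bound to an amine nitrogen in a ring, dimethylcarbamoyl in place of thiophen-2-yl gives a 4.3-fold higher number from compound 3 to compound 4 (0.63 log units; beyond the scatter) in this assay, so this single exchange on the core of compound 3 is now measured directly. The exact amide and the aromatic group on the core cannot be told apart here: dimethylamino in place of pyrrolidin-1-yl on the carbonyl carbon gives a 1.5-fold higher number from compound 1 to compound 4 (0.19 log units; within the scatter), and the exchange of the aromatic group gives a 1.7-fold higher number from compound 2 to compound 4 (0.23 log units; within the scatter). Nothing measured here explains the difference between thiophen-2-yl and dimethylcarbamoyl.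

The compounds shown leave open whether a carboxylic acid or a plain methyl on the same carbon would give a half-life like that of the amides. They also leave open how a longer chain carrying dimethylcarbamoyl would behave.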